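One Small Trim at the End of a Long Chain

The source may hold more compounds than are shown below. What is called first, only, known or untested is meant among the compounds shown, and "the series" means these compounds.

In a functional assay on the whole organism (stomach) with Rattus norvegicus as the target (on this read-out lower numbers stand for an effect already at smaller amounts and higher numbers for an effect only at larger amounts of compound), compound 1 `CCCCCC/N=C/N1CCC(C(c2ccccc2)c2ccccc2)CC1` gives 8.34 mg/kg, compound 2 `C=CC/N=C/N1CCC(C(c2ccccc2)c2ccccc2)CC1` gives 10.4 mg/kg, and compound 3 `CCCCCCCCCC/N=C/N1CCC(C(c2ccccc2)c2ccccc2)CC1` gives 7.8 mg/kg. Compound 3 therefore stands level with the other two, since all three numbers lie within the usual scatter of repeated measurements.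

The next compound to be tested is compound 4 `CCCCCCCCC/N=C/N1CCC(C(c2ccccc2)c2ccccc2)CC1`. Its difference from compound 3 is hydrogen in place of methyl on a saturated chain carbon, nine bonds along the chain from a double-bonded nitrogen, which trims the end of the long chain.

The measured steps that bear on this all changed the same chain, and each by more than this trim does. Placing butyl on a saturated chain carbon, six bonds along the chain from a double-bonded nitrogen, gave a 1.1-fold lower number from compound 1 to compound 3 (0.03 log units; within the scatter). Nonyl in place of vinyl gave a 1.3-fold lower number from compound 2 to compound 3 (0.12 log units; within the scatter), and vinyl in place of pentyl gave a 1.2-fold higher number from compound 1 to compound 2 (0.10 log units; within the scatter).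

None of these steps left the scatter, so no step beyond it is expected in this assay. The expected result is a 1.0-fold higher number from compound 3 to compound 4 (0.01 log units; within the scatter). For compound 4, the estimate is 8 mg/kg, with an expected range of 5.5 mg/kg to 11.5 mg/kg.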

Compound 4, dose for half-maximal effect: 10.8 mg/kg
Beside the measured number, compound 4's estimate is 1.4-fold (0.13 log units) below it; low and high end bracket the measured number.
By their numbers in this assay, from the lowest: compounds 3, 1, 2 and 4 (each within the scatter of the next).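

In this assay, for the compounds shown here, hydrogen in place of methyl nine bonds along the chain from a double-bonded nitrogen gives a 1.4-fold higher number from compound 3 to compound 4 (0.14 log units; within the scatter) and so, for the first time, isolates this single trim at the chain end, which stays inside the usual spread of repeat measurements. The shortened chain also reads level with the two other chains, with a 1.0-fold higher number from compound 2 to compound 4 (0.02 log units; within the scatter) for octyl in place of vinyl and a 1.3-fold higher number from compound 1 to compound 4 (0.11 log units; within the scatter) for propyl in place of hydrogen, so these four compounds show no trend with chain length in this assay. Nothing available accounts for how closely these numbers sit together.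

Going by these compounds, whether a much shorter chain such as ethyl would leave that spread remains open. So does the effect of an amine or a carboxylic acid at the chain end.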